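Swapping 4-hydroxy-2-methylphenyl for 4-ethylphenyl

The source may hold more compounds than are shown below. What is called first, only, known or untested is meant among the compounds shown, and "the series" means these compounds.

Measured so far in a functional assay on BT-549 cells (Homo sapiens) for inhibition, read by sulforhodamine B assay, with a stated time of 48 h; on this read-out higher numbers stand for weaker inhibition of growth and lower numbers for stronger inhibition of growth:
- compound 1 `Cc1ccc(C2=NN(c3ccc(S(C)(=O)=O)cc3)C(=O)CC2)cc1` gives 600 nM
- compound 2 `Cc1cc(O)ccc1C1=NN(c2ccc(S(C)(=O)=O)cc2)C(=O)CC1` gives 4970 nM

Compound 2 holds the higher of these two numbers. Compound 3 `CCc1ccc(C2=NN(c3ccc(S(C)(=O)=O)cc3)C(=O)CC2)cc1` has not been measured. Its change from compound 2 is 4-ethylphenyl in place of 4-hydroxy-2-methylphenyl on a carbon with a double bond to nitrogen on a carbon with a double bond to nitrogen. Going by the values given here, the one measured step that bears on this is an 8.3-fold higher number from compound 1 to compound 2 (0.92 log units; beyond the scatter) on exchanging 4-methylphenyl for 4-hydroxy-2-methylphenyl. The 4-ethylphenyl group looks closer to the group of compound 1 (600 nM). In this assay a step of similar size toward a lower number is therefore expected (a 7.1-fold lower number from compound 2 to compound 3 (0.85 log units; beyond the scatter)). Compound 3 is estimated at 700 nM and expected to fall between 250 nM and 2000 nM on this measure.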

Compound 3, concentration for 50% growth inhibition: 960 nM
For compound 3 the middle estimate is 1.4-fold (0.14 log units) below the measured one; the range from low to high includes it.
By their numbers in this assay, from the lowest: compounds 1 and 3 (each within the scatter of the next); then compound 2.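

In this assay, replacing 4-hydroxy-2-methylphenyl with 4-ethylphenyl restores a low number (a 5.2-fold lower number from compound 2 to compound 3 (0.71 log units; beyond the scatter)), so the high number of compound 2 does not carry over to this group. Extending the methyl of the 4-methylphenyl group to ethyl leaves the result within the scatter (a 1.6-fold higher number from compound 1 to compound 3 (0.20 log units; within the scatter)), so this position accepts either chain here. No measurement given here explains either step. On these data alone, compound 2 adds the hydroxy and the ring methyl together, so their separate contributions remain open. As far as these compounds go, how a propyl chain or an amine would behave at this position also remains open.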